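This account rests on a few compounds, and the source may have more. Where it says the series, first, only, none or still open, it means among the compounds named here.

Compound 1 `Cc1ccc(NC(=O)c2cccc(C(F)(F)F)c2)cc1OC1CCN(C(=O)c2cccnc2)CC1`: > 10000 nM (a limit)
Compound 2 `Cc1ccc(NC(=O)c2cccc(C(F)(F)F)c2)cc1OC1CCN(C(=O)c2ccccn2)CC1`: > 10000 nM (a limit)

In an ADME assay on BaF3 cells (Mus musculus) for antiproliferative activity (a higher number here means a weaker inhibitor of growth, a lower number a stronger inhibitor of growth), compound 1 gives only a limit, > 10000 nM, and so has no exact standing. Compound 2 also gives only a limit, > 10000 nM. Both therefore sit at the same boundary: the limit of > 10000 nM in this assay, at which 2 of the 2 values shown sit.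

Compound 3 `Cc1ccc(NC(=O)c2cc(C(C)(C)C)on2)cc1OC1CCN(C(=O)c2cccnc2)CC1` keeps the pyridin-3-yl carbonyl of compound 1 and carries one change: 5-(tert-butyl)-1,2-oxazol-3-yl in place of 3-(trifluoromethyl)phenyl on a carbonyl carbon. In words, 5-(tert-butyl)-1,2-oxazol-3-yl stands in place of 3-(trifluoromethyl)phenyl on a carbonyl carbon whose other neighbours are: amide-type nitrogen.

Within the data shown here, no measured step covers this replacement. The only one, a step that the two limits leave unreadable from compound 1 to compound 2, lies at the other carbonyl and has no readable size. Going by these compounds, the sole anchor is the limit of compound 1, > 10000 nM, so no step beyond the scatter is expected in this assay, and the direction stays open. For compound 3 the expected value is 8000 nM, with an estimated range of 2000 nM to 30000 nM. The expected change is an at least 1.2-fold lower number from compound 1 to compound 3 (0.09 log units; that floor lies within the scatter).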

Compound 3, concentration for 50% growth inhibition: > 10000 nM
Compound 3: only a limit was reported (the forecaster's own chance of this, stated with the estimate: 70%); at least 1.2-fold (0.09 log units) between middle value and limit.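

Compound 3 gives only a limit in this assay, as compound 1 does, so no step can be read between them, and the series stays at one boundary: the limit of > 10000 nM in this assay, at which 3 of the 3 values shown sit.

The compounds shown leave open how far each lies past that limit and whether any of these groups permits measurable growth inhibition in this assay at all.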